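Phenoxy for Dimethylamino: Cytotoxicity Stays Beyond Reach

This account rests on a few compounds, and the source may have more. Where it says the series, first, only, none or still open, it means among the compounds named here.

Compound 1 `CC(C)N(Cc1cccc(OCCCCCC(=O)O)c1)C(=O)c1ccc(-c2cccc(N(C)C)c2)cc1` was tested in an ADME assay on HEK293 cells (Homo sapiens) for cytotoxicity, read by CellTiter-Glo and resazurin assay, with a stated time of 72 h; on this read-out lower numbers stand for an effect already at smaller amounts and higher numbers for an effect only at larger amounts of compound. In this assay compound 1 gives only a limit, > 26000 nM. Compound 2 `CC(=O)c1cccc(-c2ccc(C(=O)N(Cc3cccc(OCCCCCC(=O)O)c3)C(C)C)cc2)c1` likewise gives only a limit in this assay, > 26000 nM. Among the compounds with values here, the single measured step, a step that the two limits leave unreadable from compound 1 to compound 2, cannot be sized because both values sit at the limit of > 26000 nM in this assay, at which 2 of the 2 values shown sit. Compound 3 `CC(C)N(Cc1cccc(OCCCCCC(=O)O)c1)C(=O)c1ccc(-c2cccc(Oc3ccccc3)c2)cc1` differs from compound 1 in one place: phenoxy in place of dimethylamino on an aromatic carbon. Within the data shown here, the only measured step exchanges the same dimethylamino for a different group and is itself unreadable, so no measured step shows what the change to phenoxy does. Compound 3 is thus expected to show a step that the limit leaves unreadable from compound 1 to compound 3 that stays within the scatter. The estimate for compound 3 in this assay is 40000 nM, ranging from 13000 nM to 120000 nM, most likely again only a limit.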

Compound 3, half-maximal effective concentration: > 18700 nM
Compound 3 was reported as a limit (the forecaster's own chance of this, stated with the estimate: 85%); the middle value lies beyond the limit too.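

In this assay compound 3 gives only a limit, > 18700 nM. Neither the step from compound 1 to compound 3 nor the step from compound 2 to compound 3 can be read. The compounds shown leave open whether dimethylamino, acetyl or phenoxy makes any difference to cytotoxicity.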